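The source may hold more compounds than are shown below. What is called first, only, known or untested is meant among the compounds shown, and "the series" means these compounds.

Compound 2 (`CC1(C)CC(NC(=S)Nc2ccccc2)c2cc(Cl)ccc2O1`) stands without a number in a functional assay on B16-F10 cells (Mus musculus) for inhibition, read by MTT assay, with a stated time of 72 h; on this read-out lower numbers stand for stronger inhibition and higher numbers for weaker inhibition: the entry for compound 2 reads "not determined" (no result reported) and gives no value to work from. Compound 3 (`CC1(C)CC(NC(=S)Nc2cccc([N+](=O)[O-])c2)c2cc(Cl)ccc2O1`) is still unmeasured. The structural change puts nitro in place of hydrogen on an aromatic carbon and alters nothing else. Among the compounds with values here, the only measured guide is compound 1 (`CC1(C)CC(NC(=S)Nc2cccc([N+](=O)[O-])c2)c2cc(Br)ccc2O1`), which also carries a nitro group and in this assay gives 5000 nM as its result. With no number for the starting compound, the size of the step cannot be read directly. A modest move toward stronger inhibition is expected, with a result within the usual scatter of compound 1. In this assay compound 3 is expected at about 5000 nM (estimated range 1500 nM to 16000 nM).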

Compound 3, half-maximal inhibitory concentration: 6000 nM
The estimate for compound 3 lay 1.2-fold (0.08 log units) below the measured number; low and high end bracket the measured number.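

In this assay, putting chloro in place of bromo on an aromatic carbon gives a 1.2-fold higher number from compound 1 to compound 3 (0.08 log units; within the scatter) and so leaves the two nitro compounds indistinguishable, since repeat measurements of one compound can differ as much. For this pair, then, the choice between the two halogens makes no readable difference while the nitro group stays in place, a point that compound 1 alone could not show.

Compound 2 has no number, and the steps that would show what the nitro group itself contributes cannot be read. Going by these compounds, what an amine or a carboxylic acid would do in place of the nitro group remains open, as does the effect of fluoro or methoxy in place of the chloro.

No measurement is available here that would explain these results.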